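Hydroxy to acetoxy: from compound 2 to compound 3

The source may hold more compounds than are shown below. What is called first, only, known or untested is meant among the compounds shown, and "the series" means these compounds.

Compound 1 `CC(=O)Oc1ccc2cc(-n3cc(-c4ccc(C)cc4)nn3)c(=O)oc2c1C` and compound 2 `Cc1c(O)ccc2cc(-n3cc(-c4ccc(F)cc4F)nn3)c(=O)oc12` share one core and differ in two places. In a functional assay on MCF7 cells (Homo sapiens) for antiproliferative activity (on this read-out higher numbers stand for weaker inhibition and lower numbers for stronger inhibition), compound 1 gives > 100000 nM, which is a limit of the assay and not a number. In this assay, among the measured compounds shown here, compound 2 gives 33500 nM, the only measured number here. Compound 3 `CC(=O)Oc1ccc2cc(-n3cc(-c4ccc(F)cc4F)nn3)c(=O)oc2c1C` follows from compound 2 by acetyl in place of hydrogen on an oxygen on an aromatic ring, the same change read one bond further out as hydroxy to acetoxy. For the measured compounds named here, no measured pair isolates this change. The expected step in this assay is a 1.8-fold higher number from compound 2 to compound 3 (0.25 log units; within the scatter), a modest shift toward weaker inhibition, with a fair chance of only a limit. Compound 3 is estimated at 60000 nM in this assay, within 20000 nM to 200000 nM.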

Compound 3, half-maximal inhibitory concentration: > 100000 nM
Compound 3 gave a limit, no number; the forecaster's own chance of this, stated with the estimate: 40%; middle value at least 1.6-fold (0.22 log units) away from the limit.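

In this assay, the change from hydroxy to acetoxy on the aromatic ring now has its first isolated reading: an at least 2.9-fold higher number from compound 2 to compound 3 (0.47 log units; beyond the scatter). From the compounds shown here alone, compound 3 gives > 100000 nM, which is a limit of the assay and not a number, so the true size of this step stays unknown. The step between compound 1 and compound 3 cannot be read, so 2,4-difluorophenyl against 4-methylphenyl has no size here.

Going by these compounds, how a methoxy or a carbamate on this oxygen reads in this assay stays open. Also open, on these data alone, is how 4-methylphenyl reads alongside the free hydroxy.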